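Aryl change on the chain carbon: compound 2 to compound 3

This account rests on a few compounds, and the source may have more. Where it says the series, first, only, none or still open, it means among the compounds named here.

In a functional assay for inhibition, with Homo sapiens as the target (a higher number here means a weaker inhibitor, a lower number a stronger inhibitor), compound 1 `COc1ccc(C(CC2CCCCC2)Nc2nc3ccccc3o2)cc1` gives 550 nM and compound 2 `Cc1cccc(C(CC2CCCCC2)Nc2nc3ccccc3o2)c1` gives 300 nM. Among the compounds with values here, these are the only two numbers so far, and they lie within the scatter of each other, so compound 2 has no clear standing apart from compound 1.

The next structure is compound 3 `Clc1ccccc1C(CC1CCCCC1)Nc1nc2ccccc2o1`. The change is 2-chlorophenyl in place of 3-methylphenyl on a saturated chain carbon bound to a nitrogen on an aromatic ring and a saturated chain carbon.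

Within the data shown here, one measured step bears on this place: a 1.8-fold lower number from compound 1 to compound 2 (0.26 log units; within the scatter). That exchange of 4-methoxyphenyl for 3-methylphenyl stayed within the scatter. Among the measured compounds shown here, no measured compound carries 2-chlorophenyl, so the data offer no direct reading of that group. A single small step gives no ground for a direction, and no change beyond the scatter is expected in this assay. The expected step is a 1.3-fold higher number from compound 2 to compound 3 (0.12 log units; within the scatter). For compound 3 the estimated value is 400 nM, with an expected range of 130 nM to 1200 nM.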

Compound 3, half-maximal inhibitory concentration: 80 nM
For compound 3 the middle estimate is 5.0-fold (0.70 log units) above the measured one; the whole stated range lies above it.
By their numbers in this assay, from the lowest: compound 3; then compounds 2 and 1 (each within the scatter of the next).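

In this assay the aryl group on a saturated chain carbon bound to a nitrogen on an aromatic ring and a saturated chain carbon now moves the number beyond the scatter, with a 3.8-fold lower number from compound 2 to compound 3 (0.57 log units; beyond the scatter) and a 6.9-fold lower number from compound 1 to compound 3 (0.84 log units; beyond the scatter) as the two readings. Within the data shown here, the earlier exchange, a 1.8-fold lower number from compound 1 to compound 2 (0.26 log units; within the scatter), gave no such signal, so this is the first sign that the place responds to the choice of aryl group, and compound 3 now stands lowest of the three. The groups in the 2>3 exchange have the same heavy-atom count and neither carries a hydrogen-bond donor or acceptor, so the step comes without a change in any of those counts. No measurement in hand accounts for the step.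

The compounds shown leave open whether the chlorine itself carries the step, since a phenyl ring bearing a bromine, a nitrile or an amine does not stand among them. Going by these compounds, all three share everything outside this aryl group, so how 2-chlorophenyl would read with a longer chain or a carboxylic acid elsewhere on the molecule also stays open.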